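Two benzyl-thiadiazole analogues and a sulfonyl swap

The source may hold more compounds than are shown below. What is called first, only, known or untested is meant among the compounds shown, and "the series" means these compounds.

Of the compounds shown here, three have been measured in an ADME assay on HEK-293T cells (Homo sapiens) for inhibition, read by CCK-8 assay, with a stated time of 48 h, tested at 20 uM; a lower number here means less inhibition of growth, a higher number more inhibition of growth at the concentration tested. Compound 1 `COc1ccc(Cc2nnc(NC(=O)/C(C#N)=C/c3ccccc3OS(=O)(=O)c3ccccc3[N+](=O)[O-])s2)cc1` gives 18%. Compound 2 `COc1ccc(Cc2nnc(NC(=O)/C(C#N)=C/c3ccccc3OS(=O)(=O)c3ccc(Cl)cc3)s2)cc1`, which carries 4-chlorophenyl in place of 2-nitrophenyl on a sulfonyl sulfur, gives 34%, so that a number 16 percentage points higher from compound 1 to compound 2 (beyond the scatter). Compound 3 `N#C/C(=C\c1ccccc1OS(=O)(=O)c1ccccc1[N+](=O)[O-])C(=O)Nc1nnc(Cc2ccc(F)cc2)s1` differs in its core by fluoro in place of methoxy on an aromatic carbon; in this assay compound 3 gives 6%, and a number 12 percentage points lower from compound 1 to compound 3 (beyond the scatter); compound 3 thus stands lowest of the three, with both steps to the others beyond the scatter.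

Compound 4 `N#C/C(=C\c1ccccc1OS(=O)(=O)c1ccc(Cl)cc1)C(=O)Nc1nnc(Cc2ccc(F)cc2)s1` is not yet measured. It differs from compound 3 by 4-chlorophenyl in place of 2-nitrophenyl on a sulfonyl sulfur, the same change that separates compound 2 from compound 1, at a place described in the same words in both pairs. On the basis of that one earlier step, an increase is expected from compound 3 to compound 4, estimated as a number 16 percentage points higher from compound 3 to compound 4 (beyond the scatter). Compound 4 is therefore estimated at 22% in this assay, with a plausible range from 8% to 36%, resting on a single precedent only.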

Compound 4, percent growth inhibition at one concentration: 6%
The estimate for compound 4 lay 16 percentage points above the measured number; measured number outside the range, below it.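

In this assay, the change to 4-chlorophenyl on the sulfonyl sulfur gives no change at the digits printed from compound 3 to compound 4 (within the scatter) on the fluoro core, so the rise seen on the methoxy core does not carry over: the same change on two cores in this assay, a number 16 percentage points higher (beyond the scatter) from compound 1 to compound 2 and no change at the digits printed (within the scatter) from compound 3 to compound 4, 16 percentage points apart, beyond the scatter of two such steps.
Read the other way, fluoro in place of methoxy gives a number 28 percentage points lower from compound 2 to compound 4 (beyond the scatter) when the 4-chlorophenyl group is present, and this differs from the same change with 2-nitrophenyl: the same change on two cores in this assay, a number 12 percentage points lower (beyond the scatter) from compound 1 to compound 3 and a number 28 percentage points lower (beyond the scatter) from compound 2 to compound 4, 16 percentage points apart, beyond the scatter of two such steps.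
Across these four compounds the two changes therefore do not add up, but with one pair on each core this shows only that the sulfonyl step can depend on the core, not why it does so or how general that dependence is in the series.

The compounds shown leave open how the sulfonyl change behaves when the aromatic carbon carries another group, such as an amine or a carboxylic acid. They also leave open whether a sulfonyl group bearing plain phenyl would follow either core's pattern.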